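Pyrrolidine to imidazole swap on a butynyl chain, in vivo

A few compounds are considered here, and "the series" means these few. Any claim that something is new, unique, unknown or untested is made for them only; others in the source may bear on it.

Compound 1 `CCOC(=O)N(C)CC#CCN1CCCC1` carries the pyrrolidin-1-yl group on the chain. In a functional assay on the whole organism for antagonist activity, with Mus musculus as the target (a lower number here means that less compound is needed, a higher number that more compound is needed for the effect), compound 1 gives > 100 mg/kg, which is a limit of the assay and not a number. Compound 2 `CCOC(=O)N(C)CC#CCn1ccnc1` differs from compound 1 by 1H-imidazol-1-yl in place of pyrrolidin-1-yl on a saturated chain carbon bound to a triple-bonded carbon. In this assay compound 2 gives 97 mg/kg. The step is an at least 1.0-fold lower number from compound 1 to compound 2 (0.01 log units; that floor lies within the scatter); its starting point is the limit (the limit of > 100 mg/kg in this assay, at which 1 of the 3 values shown sits), so the step carries a floor rather than a measured size.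

Compound 3 `Cn1ccn(CC#CCN2CCCC2)c1=O` has a different core; the difference between the two cores is not broken down here. In this assay compound 3 gives > 10 mg/kg, a limit and not a number. This value is the limit (the limit of > 10 mg/kg in this assay, at which 1 of the 3 values shown sits). Compound 4 `Cn1ccn(CC#CCn2ccnc2)c1=O` differs from compound 3 by 1H-imidazol-1-yl in place of pyrrolidin-1-yl on a saturated chain carbon bound to a triple-bonded carbon, the same change as made from compound 1 to compound 2, at the same place.

Among the compounds with values here, the single measured instance of this change leaves the dose for half-maximal effect essentially where it was, and the only reference for the second core is a limit. Compound 4 is therefore expected to give 40 mg/kg, with a range from 12 mg/kg to 150 mg/kg. Within the data shown here, the step expected from compound 3 to compound 4 is a step that the limit leaves unreadable from compound 3 to compound 4, which rests on the step of an at least 1.0-fold lower number from compound 1 to compound 2 (0.01 log units; that floor lies within the scatter) as the sole measured instance of the change. A further limit rather than a number is about as likely as not.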

Compound 4, dose for half-maximal effect: > 100 mg/kg
Compound 4: only a limit was reported (the forecaster's own chance of this, stated with the estimate: 50%); at least 2.5-fold (0.39 log units) between middle value and limit.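

In this assay compound 3 gives > 10 mg/kg, a limit and not a number. Compound 4 gives > 100 mg/kg, also a limit and not a number, so no step can be read from the pair compound 3 and compound 4. The compounds shown leave open whether 1H-imidazol-1-yl in place of pyrrolidin-1-yl changes the dose for half-maximal effect on either core.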